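This account rests on a few compounds, and the source may have more. Where it says the series, first, only, none or still open, it means among the compounds named here.

Compound 3 `CCNc1n[n+]([O-])c2cc(Br)ccc2[n+]1[O-]` stands at the low end of the three numbers in an ADME assay on Vero cells (Chlorocebus sabaeus) for cytotoxicity, read by CellTiter-Glo, with a stated time of 72 h (on this read-out lower numbers stand for higher toxicity in this test and higher numbers for lower toxicity in this test), where compound 3 gives 4.2 ug/mL; the gap a 1.1-fold lower number from compound 2 to compound 3 (0.04 log units; within the scatter) is within the scatter, compound 2 `CCNc1n[n+]([O-])c2cc(F)ccc2[n+]1[O-]` giving 4.6 ug/mL, whereas compound 1 `CCNc1n[n+]([O-])c2ccccc2[n+]1[O-]` gives 17 ug/mL, with a 4.0-fold lower number from compound 1 to compound 3 (0.61 log units; beyond the scatter). Compound 4 `CCNc1n[n+]([O-])c2cc(OC)ccc2[n+]1[O-]` differs from compound 3 in one place: methoxy in place of bromo on an aromatic carbon. Among the compounds with values here, the steps that bear on this are a 3.7-fold lower number from compound 1 to compound 2 (0.57 log units; beyond the scatter) and a 4.0-fold lower number from compound 1 to compound 3 (0.61 log units; beyond the scatter), both modest, and a 1.1-fold lower number from compound 2 to compound 3 (0.04 log units; within the scatter), within the scatter. Within the data shown here, no methoxy analogue has been measured, so the halogen steps give only indirect guidance. Compound 4 is therefore expected to show a small rise, a 1.9-fold higher number from compound 3 to compound 4 (0.28 log units; within the scatter), toward compound 1. The estimate for compound 4 in this assay is 8 ug/mL, between 3.5 ug/mL and 18 ug/mL.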

Compound 4, half-maximal cytotoxic concentration: 16 ug/mL
For compound 4 the middle estimate is 2.0-fold (0.30 log units) below the measured one, within the range that was stated.
By their numbers in this assay, from the lowest: compounds 3 and 2 (each within the scatter of the next); then compounds 4 and 1 (each within the scatter of the next).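

In this assay methoxy at this position does not follow the two halogens, with a 3.8-fold higher number from compound 3 to compound 4 (0.58 log units; beyond the scatter) and a 3.5-fold higher number from compound 2 to compound 4 (0.54 log units; beyond the scatter) on replacing bromo and fluoro. Against hydrogen the step is a 1.1-fold lower number from compound 1 to compound 4 (0.03 log units; within the scatter) and lies within the scatter, so a group at this position does not by itself bring the lower numbers seen with fluoro and bromo. Nothing measured here accounts for this difference between methoxy and the halogens. Going by these compounds, whether an amine or a longer ether such as ethoxy at this position would give numbers like those of the halogens or like that of hydrogen stays open.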